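The compounds below may be only part of what the source reports. "The series", "measured", "known", "first", "only" and "open" are said of these compounds alone.

Three compounds built on a shared core have been examined in a functional assay on MRC5 cells (Homo sapiens); a lower number here means that less compound is tolerated, a higher number that more compound is tolerated. Compound 1 `O=C1c2ccccc2N(Cc2ccc(C(F)(F)F)cc2)S(=O)(=O)N1Cc1ccc(C(F)(F)F)cc1` gives 48000 nM in this assay. Compound 3 `O=S1(=O)N=C(OCc2ccccc2-c2ccccc2)c2ccccc2N1Cc1ccccc1-c1ccccc1` gives 47000 nM in this assay. Compound 2 `O=C1c2ccccc2N(Cc2ccccc2-c2ccccc2)S(=O)(=O)N1Cc1ccccc1-c1ccccc1` returns only a limit of the assay, > 47000 nM. The position of compound 2 is thus known only as a range, as shown by the limit of > 47000 nM in this assay, at which 1 of the 3 values shown sits, and all three compounds cluster at the high end of what this assay reports, with no separation beyond the scatter between compound 1 and compound 3.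

The unmeasured compound 4 `O=C1c2ccccc2N(Cc2ccccc2-c2ccccc2)S(=O)(=O)N1Cc1ccccc1` differs from compound 2 by hydrogen in place of phenyl on an aromatic carbon. Among the measured compounds shown here, no measured pair shows this change, so its size in this assay is unknown; the expectation is for no step beyond the scatter, in either direction. Compound 4 is therefore expected to give about 47000 nM, within a range from 20000 nM to 100000 nM. The expected step is a number no higher from compound 2 to compound 4 (the limit leaves the size open), essentially none.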

Compound 4, half-maximal cytotoxic concentration: > 55000 nM
Compound 4 ended at the assay's limit; the forecaster's own chance of this, stated with the estimate: 50%; middle value at least 1.1-fold (0.06 log units) from the limit.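

In this assay, among the compounds shown here, compound 4 returns only a limit of > 55000 nM and compound 2 also stands at a limit, so no step between them can be read. The compounds shown leave open whether hydrogen in place of phenyl on an aromatic carbon changes this read-out at all.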